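Isopropylcarbamoyl replaces cyclopentylmethyl on the shared core

The compounds below may be only part of what the source reports. "The series", "measured", "known", "first", "only" and "open" are said of these compounds alone.

Compound 1, `CCCCCNc1nc(N)nc2ccccc12`: 0.1 uM
Compound 2, `CCCCNc1nc(N)nc2ccc(C#N)cc12`: 7.1 uM
Compound 3, `CCCCNc1nc(N)nc2cccc(CC3CCCC3)c12`: > 25 uM, a limit of the assay

The three measured compounds share one core and differ in the alkylamino chain and in what sits on the six-membered carbon ring. In an ADME assay on HEK293 cells for agonist activity at Toll-like receptor 8 (Homo sapiens), read by a luciferase reporter, with a stated time of 6 h (a lower number here means that less compound is needed, a higher number that more compound is needed for the effect), compound 1 gives 0.1 uM, and compound 2 gives 7.1 uM. Compound 3 gives no number at all but only a limit of the assay, > 25 uM. On these data alone, this is the limit of > 25 uM in this assay, at which 1 of the 3 values shown sits, so compound 3 stands at the far, weaker end of what the three values show, and its true value is unknown beyond that boundary.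

Compound 4, `CCCCNc1nc(N)nc2cccc(C(=O)NC(C)C)c12`, has not yet been measured in this assay. It differs from compound 3 in one place: isopropylcarbamoyl in place of cyclopentylmethyl on an aromatic carbon. Within the data shown here, no two measured compounds differ in only one place, so no measured step tells how strongly this assay answers such a change. With compound 3 at a limit, any step that yields a number must go toward a lower concentration; a step beyond the usual scatter, toward a lower number, is expected, with its size uncertain.

Compound 4 is expected to give about 8 uM, most likely between 1.5 uM and 25 uM. That estimate amounts to an expected step of an at least 3.1-fold lower number from compound 3 to compound 4 (0.49 log units; beyond the scatter), toward a lower number.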

Compound 4, minimum effective concentration: 15.6 uM
Beside the measured number, compound 4's estimate is 2.0-fold (0.29 log units) below it; the measured number falls inside the stated range.
By their numbers in this assay, from the lowest: compound 1; then compound 2; then compound 4. At a limit, above all of these: compound 3.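

At this place on an aromatic carbon, ortho to a fused ring and meta to a fused ring, isopropylcarbamoyl gives a number in this assay, with compound 4 at 15.6 uM, so a group with a hydrogen-bond donor and a hydrogen-bond acceptor on this carbon still reads inside the range of the assay. Compound 3, with cyclopentylmethyl on the same carbon, stands at a limit of the assay, > 25 uM, and nothing more exact can be said of it. The change of group is an at least 1.6-fold lower number from compound 3 to compound 4 (0.20 log units; that floor lies within the scatter), so only a floor can be given for this step, and that floor does not establish a real gain, because one end of the pair is a limit rather than a number: the limit of > 25 uM in this assay, at which 1 of the 4 values shown sits.

The compounds shown leave open how this carbon would answer a primary amine, a carboxylic acid or a smaller amide such as an unsubstituted carbamoyl group, and how far the true step from cyclopentylmethyl runs. Among these compounds, they also leave open how the shared core would read with only hydrogen on this carbon, the one comparison that would show whether either group helps or hurts.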